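Cytotoxicity in the shared core: ester at the benzylic carbon

A few compounds are considered here, and "the series" means these few. Any claim that something is new, unique, unknown or untested is made for them only; others in the source may bear on it.

Compound 1 `Cc1c(F)c(N)c2c(=O)cc(-c3ccc(N)c(F)c3)oc2c1F` carries a methyl on its core. In a functional assay on HeLa cells (Homo sapiens) for cytotoxicity, read by neutral red uptake, with a stated time of 3 days (on this read-out higher numbers stand for weaker inhibition and lower numbers for stronger inhibition), compound 1 gives > 100000 nM, which is a limit of the assay rather than a number. Two of the three measured values sit at this limit (the limit of > 100000 nM in this assay, at which 2 of the 3 values shown sit), so compound 1 cannot be ranked against compound 3 `Nc1ccc(-c2cc(=O)c3c(N)c(F)c(C(=O)O)c(F)c3o2)cc1F`, for which the assay also reports only a limit; in this assay compound 3 gives > 100000 nM. For the measured compounds named here, compound 2 `COc1c(F)c(N)c2c(=O)cc(-c3ccc(N)c(F)c3)oc2c1F` is the only member with a numeric value: in this assay compound 2 gives 34000 nM. The change from methyl to methoxy gives an at least 2.9-fold lower number from compound 1 to compound 2 (0.46 log units; beyond the scatter), while the change from methoxy to carboxy gives an at least 2.9-fold higher number from compound 2 to compound 3 (0.46 log units; beyond the scatter). The step that the two limits leave unreadable from compound 1 to compound 3 cannot be sized.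

Compound 4 `CCC(=O)OCc1c(F)c(N)c2c(=O)cc(-c3ccc(N)c(F)c3)oc2c1F` differs from compound 1 by propanoyloxy in place of hydrogen on a saturated chain carbon bound to an aromatic carbon. Both measured steps start from the same methyl of compound 1 and replace it, whereas here the methyl is kept and extended; neither step involves an ester, so neither bears directly on this change. With compound 1 standing at the limit, any expectation rests on that limit alone, and no step beyond the scatter is expected in either direction. The expected step is an at least 1.2-fold lower number from compound 1 to compound 4 (0.09 log units; that floor lies within the scatter). Compound 4 is therefore estimated at 80000 nM, within the range 20000 nM to 300000 nM, with a substantial chance that only a limit is reported.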

Compound 4, half-maximal inhibitory concentration: 69000 nM
Compound 4: middle estimate off by 1.2-fold (0.06 log units), on the high side; the measured number falls inside the stated range.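

For the compounds shown here, the (propanoyloxy)methyl group gives the series its second numeric value in this assay, and the only one from a group that keeps the carbon of the methyl of compound 1. This allows a comparison between two numbers at this position, which shows a 2.0-fold higher number from compound 2 to compound 4 (0.31 log units; beyond the scatter), a modest step with the ester-bearing compound on the weaker side. The other two steps show less, namely an at least 1.4-fold lower number from compound 1 to compound 4 (0.16 log units; that floor lies within the scatter) and an at least 1.4-fold lower number from compound 3 to compound 4 (0.16 log units; that floor lies within the scatter), since each starts from a limit and its floor does not separate compound 4 from the compound at the limit: the limit of > 100000 nM in this assay, at which 2 of the 4 values shown sit.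

Still open, on these data alone, is how far the true values of compound 1 and compound 3 lie from compound 4, so the actual size of those two steps is unknown. Also open, as far as these compounds go, is how the same saturated chain carbon would read with a free hydroxyl, an amine or a longer acyl chain such as butanoyloxy, and whether any of these would fall on the side of compound 2 or nearer the limit.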